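Trading fluoro for amino on an aromatic ring

The compounds below may be only part of what the source reports. "The series", "measured", "known", "first", "only" and "open" are said of these compounds alone.

- Compound 1 `Nc1nc(Nc2ccc(S(N)(=O)=O)cc2)sc1C(=O)c1ccccc1[N+](=O)[O-]`: 1400 nM
- Compound 2 `Nc1nc(Nc2ccc(S(N)(=O)=O)cc2)sc1C(=O)c1cccc(F)c1`: 1600 nM

In a functional assay on SK-UT-1 cells (Homo sapiens) for cytotoxicity, read by fluorescence and resazurin assay, with a stated time of 72 h (on this read-out lower numbers stand for stronger inhibition and higher numbers for weaker inhibition), compound 2 gives 1600 nM, within the usual scatter of compound 1 at 1400 nM. Compound 3 `Nc1cccc(C(=O)c2sc(Nc3ccc(S(N)(=O)=O)cc3)nc2N)c1` keeps the core of compound 2 and changes one group on an aromatic carbon: amino in place of fluoro on an aromatic carbon. Going by the values given here, the only measured step, a 1.1-fold higher number from compound 1 to compound 2 (0.06 log units; within the scatter), also swapped a group on that ring and stayed small, so no step beyond the scatter is expected in this assay. The estimated step is a 1.3-fold lower number from compound 2 to compound 3 (0.12 log units; within the scatter). For compound 3 the expected value is 1200 nM, within an estimated range of 450 nM to 3200 nM.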

Compound 3, half-maximal inhibitory concentration: > 10000 nM
Compound 3 was reported as a limit; the forecaster's own chance of this, stated with the estimate: 3%; middle value at least 8.3-fold (0.92 log units) away from the limit.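

Compound 3 is reported only as a limit, not as a number: the limit of > 10000 nM in this assay, at which 1 of the 3 values shown sits.

The ring carrying this group is not as forgiving as the earlier pair suggested. That pair gave a 1.1-fold higher number from compound 1 to compound 2 (0.06 log units; within the scatter), whereas amino in place of fluoro gives an at least 6.2-fold higher number from compound 2 to compound 3 (0.79 log units; beyond the scatter), and 3-aminophenyl in place of 2-nitrophenyl gives an at least 7.1-fold higher number from compound 1 to compound 3 (0.85 log units; beyond the scatter).

The compounds shown do not tell why amino differs from fluoro here, or how far compound 3 lies past its limit. They also leave open whether a hydroxyl, a methoxy or an acetylated amino group at this place would behave like fluoro or like amino.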